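Dimethylamino in place of methoxysulfonyl on the shared core

This account rests on a few compounds, and the source may have more. Where it says the series, first, only, none or still open, it means among the compounds named here.

Measured in a physicochemical assay for lipophilicity; a lower number here means a more polar compound, a higher number a more lipophilic compound:
compound 1 `CC(C)c1cc(Br)cc(C(C)C)c1O`: 5.49
compound 2 `CC(C)c1cc(I)cc(C(C)C)c1O`: 5.75
compound 3 `COS(=O)(=O)c1cc(C(C)C)c(O)c(C(C)C)c1`: 3.7

Compound 3 gives the lowest of the three measured values, at 3.7. The next structure, compound 4 `CC(C)c1cc(N(C)C)cc(C(C)C)c1O`, carries dimethylamino in place of methoxysulfonyl on an aromatic carbon. Within the data shown here, two measured steps bear on this change: a number 1.79 log units lower from compound 1 to compound 3 (beyond the scatter) and a number 2.05 log units lower from compound 2 to compound 3 (beyond the scatter), both large and beyond the scatter. The halogen swap, a number 0.26 log units higher from compound 1 to compound 2 (within the scatter), stays within the scatter. Among the measured compounds shown here, no measured compound carries dimethylamino, so these steps support only a direction: a rise is expected on losing methoxysulfonyl, probably smaller than either of them. The expected step is a number 1.00 log units higher from compound 3 to compound 4 (beyond the scatter), beyond the scatter. Compound 4 is estimated at 4.7, with an expected range from 4.1 to 5.3.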

Compound 4, partition coefficient: 4.52
Beside the measured number, compound 4's estimate is 0.18 log units above it, and the stated range covers the measured number.
By their numbers in this assay, from the lowest: compound 3; then compound 4; then compounds 1 and 2 (each within the scatter of the next).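

In this assay, among these compounds, dimethylamino at this aromatic carbon, para to a hydroxy group, gives a level not seen in the earlier compounds: a number 0.82 log units higher from compound 3 to compound 4 (beyond the scatter), but also a number 0.97 log units lower from compound 1 to compound 4 (beyond the scatter) and a number 1.23 log units lower from compound 2 to compound 4 (beyond the scatter). Compound 4 therefore lies between compound 3 and the two halogen compounds, with each of these steps beyond the scatter. Nothing available explains this order.

Still open, going by these compounds, is where a primary amine or a carboxylic acid at this position would fall relative to compound 3 and compound 4. Also open, on these data alone, is whether the same order holds on a core without the hydroxy group.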